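The source may report more compounds than this note shows. Statements on the series, on what has been measured and on what is new or still open speak of the compounds shown alone.

Of the compounds shown here, two have been tested for antiproliferative activity in a functional assay on HCT-15 cells (Homo sapiens) for antiproliferative activity; on this read-out higher numbers stand for an effect only at larger amounts of compound and lower numbers for an effect already at smaller amounts. Compound 1 `c1ccc(-c2cc(-c3cccs3)nc(-c3cccs3)c2)nc1` carries a pyridin-2-yl group together with two thiophen-2-yl groups on the shared core; in this assay compound 1 gives 118000 nM. Compound 2 `C(=C/c1ccco1)\c1cc(-c2ccco2)cc(-c2cccs2)n1` differs from it in more than one place, and in this assay compound 2 gives 118000 nM. Compound 2 therefore stands level with compound 1 at the digits recorded, and the two values lie within the scatter of one another, so no order between them can be read off.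

Compound 3 `c1coc(-c2cc(-c3cccs3)nc(-c3cccs3)c2)c1` is not yet measured. Compared with compound 2 the change is thiophen-2-yl in place of 2-(furan-2-yl)ethenyl on an aromatic carbon. Going by the values given here, no pair of measured compounds isolates this change, and the two recorded values give nothing that points in either direction. For compound 3 the step is expected to be no change at the digits printed from compound 2 to compound 3 (within the scatter), none beyond the scatter. Compound 3 is accordingly estimated at 118000 nM, with a range from 50000 nM to 200000 nM.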

Compound 3, half-maximal effective concentration: 118000 nM
Estimate against measurement, compound 3: no gap at the digits printed; the range from low to high includes it.
By their numbers in this assay, from the lowest: compounds 1, 2 and 3 (each within the scatter of the next).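

Going by these compounds alone, the two earlier compounds differed in more than one place, so compound 3 supplies the first single-place comparisons in this assay. On the aromatic carbon next to the ring nitrogen, thiophen-2-yl in place of 2-(furan-2-yl)ethenyl gives no change at the digits printed from compound 2 to compound 3 (within the scatter), so going from 7 heavy atoms to 5 and losing the double bond outside the aromatic rings leaves the read-out where it was. On an aromatic carbon, furan-2-yl in place of pyridin-2-yl gives no change at the digits printed from compound 1 to compound 3 (within the scatter), so this exchange of one aromatic ring for another also shows no step, and nothing measured here explains why either exchange leaves the value in place.

The compounds shown leave open whether any group at the carbon next to the ring nitrogen can move the value in this assay, for instance an amine, a carboxylic acid or a longer alkyl chain. They also leave open whether the two exchanges would read the same on a core carrying such a group elsewhere, as all three compounds hold only aromatic rings and, in compound 2, the ethenyl link.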